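The source may hold more compounds than are shown below. What is called first, only, known or untested is meant among the compounds shown, and "the series" means these compounds.

Compound 1 `Cc1cc(C)cc(S(=O)(=O)c2c(C(=O)NCc3n[nH]c4ccccc34)[nH]c3ccc(Cl)cc23)c1`: > 50700 nM
Compound 2 `Cc1cc(C)cc(S(=O)(=O)c2c(C(=O)Nc3cc(C#N)ccn3)[nH]c3ccc(Cl)cc23)c1`: > 53700 nM

In an ADME assay on MT4 cells (Homo sapiens) for cytotoxicity, read by MTT assay (a lower number here means that less compound is tolerated, a higher number that more compound is tolerated), compound 1 gives > 50700 nM, which is a limit of the assay and not a number. Compound 2 gives > 53700 nM, and this too is only a limit. Neither measured compound therefore has an exact value.

Compound 3 `Cc1cc(C)cc(S(=O)(=O)c2c(C(=O)NCC(=O)NCc3ccccc3F)[nH]c3ccc(Cl)cc23)c1` keeps the shared core and changes only the group on the amide-type nitrogen: ((2-fluorobenzyl)carbamoyl)methyl in place of 4-cyanopyridin-2-yl on an amide-type nitrogen. Among the measured compounds shown here, the one measured step changes the group at this same place: a step that the two limits leave unreadable from compound 1 to compound 2. It offers no size to carry over, but two different groups here both ended at limits. No step beyond the usual scatter is therefore expected in this assay, and the assay may again report only a limit. The expected change is an at least 1.1-fold lower number from compound 2 to compound 3 (0.07 log units; that floor lies within the scatter). For compound 3 the estimate is 45000 nM, with an expected range from 15000 nM to 60000 nM.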

Compound 3, half-maximal cytotoxic concentration: > 47300 nM
Compound 3: no number, only a limit; the forecaster's own chance of this, stated with the estimate: 70%; at least 1.0-fold (0.02 log units) between middle value and limit.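

In this assay compound 3 again gives only a limit, and its steps from compound 1 and from compound 2 cannot be read. The compounds shown leave open the concentration at which any of the three harms these cells, and whether the group on the amide-type nitrogen matters here.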